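Series notes: cyanophenyl to fluorophenyl at the chain carbon

A few compounds are considered here, and "the series" means these few. Any claim that something is new, unique, unknown or untested is made for them only; others in the source may bear on it.

Compound 1 `COc1ccc(Cc2cnc(CCc3ccc(-c4ccccc4C(=O)O)cc3)[nH]2)cc1` and compound 2 `N#Cc1ccc(Cc2cnc(CCc3ccc(-c4ccccc4C(=O)O)cc3)[nH]2)cc1` have the shared core and differ in one aromatic substituent. In an in vitro functional assay on cells for agonist activity at Bombesin receptor subtype-3 (Homo sapiens), read by luminescence and calcium flux (on this read-out lower numbers stand for an effect already at smaller amounts and higher numbers for an effect only at larger amounts of compound), compound 1 gives 5360 nM. In this assay compound 2 gives 5890 nM, the highest of the two numbers, yet the step of a 1.1-fold higher number from compound 1 to compound 2 (0.04 log units; within the scatter) leaves the two values indistinguishable. Compound 3 `O=C(O)c1ccccc1-c1ccc(CCc2ncc(Cc3cccc(F)c3)[nH]2)cc1` has not yet been measured. Relative to compound 2 the change is 3-fluorophenyl in place of 4-cyanophenyl on a saturated chain carbon bound to an aromatic carbon. For the measured compounds named here, no measured step covers this exact exchange; the only step in hand, a 1.1-fold higher number from compound 1 to compound 2 (0.04 log units; within the scatter), shows that swapping one substituent for another on the same group moved the number little. On that basis a step of about a 1.1-fold lower number from compound 2 to compound 3 (0.03 log units; within the scatter) is expected in this assay, with no direction beyond the scatter. Compound 3 is therefore estimated at 5500 nM in this assay, with a range from 2000 nM to 15000 nM.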

Compound 3, half-maximal effective concentration: 159 nM
Estimate against measurement, compound 3: 35-fold (1.54 log units) above, and the stated range ends above it.
By their numbers in this assay, from the lowest: compound 3; then compounds 1 and 2 (each within the scatter of the next).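

In this assay the place on a saturated chain carbon bound to an aromatic carbon proves able to move the number a long way: 3-fluorophenyl in place of 4-cyanophenyl gives a 37-fold lower number from compound 2 to compound 3 (1.57 log units; beyond the scatter) and 3-fluorophenyl in place of 4-methoxyphenyl gives a 34-fold lower number from compound 1 to compound 3 (1.53 log units; beyond the scatter) at the same place. The earlier pair gave no sign of this, with 4-methoxyphenyl and 4-cyanophenyl lying within the scatter of each other. No independent measurement bears on the reason for the drop.

The compounds shown leave open whether the step follows the fluorine or the 3-position: compound 3 differs from compound 1 and compound 2 in both the substituent and where it sits. A 4-fluorophenyl or a 3-cyanophenyl group at this place would separate the two, and an unsubstituted phenyl group would give the baseline for both.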